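The source may report more compounds than this note shows. Statements on the series, on what has been measured and on what is new or still open speak of the compounds shown alone.

Measured compounds: compound 1 `CCN(CC)CCNC(=O)c1ccc(C(CC)(CC)c2ccc(OCC(=O)C(C)(C)C)c(C)c2)n1CC`, compound 2 `CCn1c(C(=O)NCCCN(C)C)ccc1C(CC)(CC)c1ccc(OCC(=O)C(C)(C)C)c(C)c1`, compound 3 `CCn1c(C(=O)NCC(OC)OC)ccc1C(CC)(CC)c1ccc(OCC(O)C(C)(C)C)c(C)c1`.

In a functional assay on Caco-2 cells (Homo sapiens), read by MTT assay, with a stated time of 48 h (on this read-out higher numbers stand for weaker inhibition and lower numbers for stronger inhibition), compound 1 gives 1600 nM. Compound 2 gives 1400 nM in this assay, and a 1.1-fold lower number from compound 1 to compound 2 (0.06 log units; within the scatter). In this assay compound 3 gives > 50000 nM, which is a limit of the assay and not a number. Compound 3 therefore sits at the limit of > 50000 nM in this assay, at which 1 of the 3 values shown sits, apart from compounds 1 and 2.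

Compound 4 `CCn1c(C(=O)OCc2ccc(F)cc2)ccc1C(CC)(CC)c1ccc(OCC(O)C(C)(C)C)c(C)c1` differs from compound 3 by (4-fluorobenzyl)oxy in place of (2,2-dimethoxyethyl)amino on a carbonyl carbon. Among the measured compounds shown here, no measured step touches this carbonyl carbon; the only measured step, from compound 1 to compound 2, concerns a saturated chain carbon and does not bear on it. The expectation thus rests on compound 3 alone, whose limit gives no number to step from. Compound 4 is expected near 30000 nM, within 5000 nM to 100000 nM, the estimated step being an at least 1.6-fold lower number from compound 3 to compound 4 (0.22 log units; that floor lies within the scatter), with a fair chance that only a limit is again reported.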

Compound 4, half-maximal inhibitory concentration: > 50000 nM
Compound 4 was reported as a limit (the forecaster's own chance of this, stated with the estimate: 55%); at least 1.6-fold (0.22 log units) between middle value and limit.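

No step can be read between compound 3 and compound 4 in this assay, since both values are limits and not numbers: the limit of > 50000 nM in this assay, at which 2 of the 4 values shown sit.

On these data alone, whether (4-fluorobenzyl)oxy or (2,2-dimethoxyethyl)amino on the carbonyl carbon gives stronger inhibition remains open.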